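The compounds below may be only part of what the source reports. "The series", "measured", "known", "first", "only" and "open" are said of these compounds alone.

Measured so far in an ADME assay on HepG2 cells (Homo sapiens) for cytotoxicity, with a stated time of 72 h; on this read-out lower numbers stand for an effect already at smaller amounts and higher numbers for an effect only at larger amounts of compound:
- compound 1 `Cc1cc(NC(=O)Nc2ccc(C(C)(C)C)cc2)c2ccccc2n1`: 17000 nM
- compound 2 `Cc1cc(NC(=O)Nc2ccc(C)c(Cl)c2)c2ccccc2n1`: > 25000 nM
- compound 3 `Cc1cc(NC(=O)Nc2ccc(Cl)c(Cl)c2)c2ccccc2n1`: 17000 nM

Compound 1 stands level with compound 3, which also gives 17000 nM. The reading for compound 2, > 25000 nM, is a limit of the assay and not a number.

Compound 4 `CCc1ccc(NC(=O)Nc2cc(C)nc3ccccc23)cc1` has not yet been measured. It differs from compound 1 in one place: ethyl in place of tert-butyl on an aromatic carbon. In words, this is ethyl in place of tert-butyl on an aromatic carbon, para to a large group.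

Within the data shown here, only one measured step changes a single group, an at least 1.4-fold lower number from compound 2 to compound 3 (0.16 log units; that floor lies within the scatter). That step is chloro in place of methyl, so it involves neither group exchanged here and offers only indirect guidance. Among the measured compounds shown here, no measured step replaces tert-butyl or introduces ethyl. With so little to suggest a real shift, the starting point is compound 1 at 17000 nM, and no change beyond the scatter is expected in this assay. The expected change is a 1.2-fold higher number from compound 1 to compound 4 (0.07 log units; within the scatter), which is within the scatter. Compound 4 could also reach (the limit of > 25000 nM in this assay, at which 1 of the 3 values shown sits), and would then give no exact number. For compound 4 the estimated value is 20000 nM, with an expected range from 12000 nM to 32000 nM.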

Compound 4, half-maximal effective concentration: 17000 nM
Beside the measured number, compound 4's estimate is 1.2-fold (0.07 log units) above it, within the range that was stated.
By their numbers in this assay, from the lowest: compounds 1, 3 and 4 (each within the scatter of the next). At a limit, above all of these: compound 2.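

In this assay, exchanging the group on the aromatic carbon para to a large group gives no change at the digits printed from compound 1 to compound 4 (within the scatter). This is the only measured step shown that changes tert-butyl itself; the earlier step exchanged methyl for chloro, so it gave no reading on this group or on ethyl. Here, going from a group of 4 carbon atoms to one of 2 leaves the read-out within the scatter, which holds for this one pair of compounds and is not a rule for the series.

An amine, a carboxylic acid or a longer chain such as hexyl at this place could give a different picture, and the compounds shown offer no reading on any of these groups. Compound 2 gives a limit and not a number, so how far it stands from an exact value stays open: the limit of > 25000 nM in this assay, at which 1 of the 4 values shown sits.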